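This account rests on a few compounds, and the source may have more. Where it says the series, first, only, none or still open, it means among the compounds named here.

Measured so far:
compound 1, `COc1ccccc1N1CCn2c1n[nH]c(=O)c2=O` — 17%
compound 2, `Cc1cccc(N2CCn3c2n[nH]c(=O)c3=O)c1C` — 18%

In an ADME assay on Vero cells (Chlorocebus sabaeus) for cytotoxicity, with a stated time of 72 h, tested at 50 ug/mL (a higher number here means a stronger effect of the compound at the concentration tested, a lower number a weaker effect), compound 2 gives 18% and compound 1 gives 17%. The two numbers lie within the usual scatter of each other, so compound 2 stands level with compound 1 rather than apart from it. For the measured compounds named here, no change in a single place between measured compounds has been recorded, so there is no measured step to lean on.

Compound 3, `Cc1ccccc1N1CCn2c1n[nH]c(=O)c2=O`, is the next compound for this assay. Relative to compound 2 it carries hydrogen in place of methyl on an aromatic carbon. The expectation rests only on compound 2 with 18% and compound 1 with 17%, which sit close together. The step is expected to stay within the scatter, with no clear direction: a number 1 percentage points lower from compound 2 to compound 3 (within the scatter). Compound 3 is therefore expected to give 17% in this assay, with a range from 8% to 27%.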

Compound 3, a percentage reported as inhibition, at one concentration (the size of the read-out at that concentration, not a potency): 0%
Beside the measured number, compound 3's estimate is 17 percentage points above it, and the stated range ends above it.
By their numbers in this assay, from the lowest: compound 3; then compounds 1 and 2 (each within the scatter of the next).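

In this assay, hydrogen in place of methyl on an aromatic carbon, ortho to a methyl group, is a change that registers: it gives a number 18 percentage points lower from compound 2 to compound 3 (beyond the scatter). Methyl in place of methoxy on an aromatic carbon gives a number 17 percentage points lower from compound 1 to compound 3 (beyond the scatter), so two different single changes each separate compound 3 from a compound that reads higher, although compounds 1 and 2 stand level with each other. Nothing measured here offers a reason for either step.

Still open, from the compounds shown here alone, is how the number moves with a fluorine, an amine or a carboxylic acid on this aromatic carbon. Also open, going by these compounds, is whether hydrogen in place of the remaining methyl of compound 3 would shift the read-out at all.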